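The source may report more compounds than this note shows. Statements on the series, on what has been measured and on what is new or still open speak of the compounds shown alone.

Compound 1 `c1ccc(COc2ccc(OCCOCCNc3ccncc3)cc2)cc1`: 20600 nM
Compound 2 `c1ccc(COc2ccc(OCCOCCNc3ccccc3)cc2)cc1`: > 100000 nM

Both results come from a functional assay on SK-OV-3 cells (Homo sapiens) for inhibition, read by CCK-8 assay, with a stated time of 70 h; on this read-out higher numbers stand for weaker inhibition and lower numbers for stronger inhibition. Compound 2 stands at > 100000 nM, which is a limit of the assay and not a number. Compound 3 `c1ccc(COc2ccc(OCCOCCNc3cc[nH]c3)cc2)cc1` has 1H-pyrrol-3-yl in place of phenyl on an amine nitrogen. Within the data shown here, one measured step bears on this change: an at least 4.8-fold higher number from compound 1 to compound 2 (0.68 log units; beyond the scatter), with phenyl replacing pyridin-4-yl. Both 1H-pyrrol-3-yl and pyridin-4-yl contain nitrogen, so a move toward stronger inhibition is expected, of modest size, and the result could still remain at the limit. The expected step is an at least 2.2-fold lower number from compound 2 to compound 3 (0.34 log units; beyond the scatter). For compound 3 the estimate is 45000 nM, with an expected range of 15000 nM to 100000 nM.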

Compound 3, half-maximal inhibitory concentration: 11300 nM
Beside the measured number, compound 3's estimate is 4.0-fold (0.60 log units) above it, outside the stated range (below it).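

With 1H-pyrrol-3-yl on the amine nitrogen, this assay gives an at least 8.8-fold lower number from compound 2 to compound 3 (0.94 log units; beyond the scatter). Pyridin-4-yl is therefore not the only nitrogen-containing ring that gives a measurable value at this place, and the two rings cannot be separated, with a 1.8-fold lower number from compound 1 to compound 3 (0.26 log units; within the scatter). The value of compound 2 is a limit of the assay and not a number, so the full size of its step stays unknown: the limit of > 100000 nM in this assay, at which 1 of the 3 values shown sits.

Still open, on these data alone, is whether the ring nitrogen itself matters, or only the change away from phenyl. Thiophen-3-yl, with sulfur in the ring, and pyridin-3-yl, with the nitrogen moved, would help to separate these.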